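Methylating the amide nitrogen in a paw edema series

The source may hold more compounds than are shown below. What is called first, only, known or untested is meant among the compounds shown, and "the series" means these compounds.

Two compounds have been measured in a functional assay on the whole organism (strain Wistar) for inhibition, with Rattus norvegicus as the target, read by paw edema, with stated times of 60 min and 6 h, at a dose of 100 mg/kg by the oral route; a lower number here means less inhibition, a higher number more inhibition at the dose given (going by the name of the read-out):

compound 1, `COc1cc2c(cc1OC)C(CC(=O)O)CC2`: 20.4%
compound 2, `CNC(=O)CC1CCc2cc(OC)c(OC)cc21`: 24.1%

Going by the values given here, compound 2 holds the higher of the two numbers, yet the only measured step, a number 3.7 percentage points higher from compound 1 to compound 2 (within the scatter), lies within the scatter, so the two compounds cannot be told apart on these numbers. Compound 3, `COc1cc2c(cc1OC)C(CC(=O)N(C)C)CC2`, has not yet been measured. It differs from compound 2 in one place: methyl in place of hydrogen on an amide-type nitrogen. Among the compounds with values here, no measured pair shows this particular change; the one step available, a number 3.7 percentage points higher from compound 1 to compound 2 (within the scatter), concerns a different place and stayed within the scatter. With nothing pointing to movement in either direction, no step beyond the scatter is expected for compound 3. Compound 3 is therefore estimated at 22%, with a range from 8% to 38%. That estimate amounts to an expected step of a number 2.1 percentage points lower from compound 2 to compound 3 (within the scatter).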

Compound 3, a percentage reported as inhibition, in the whole organism at one dose (the size of the read-out at that dose, not a potency): 33.3%
Estimate against measurement, compound 3: 11.3 percentage points below; the measured number falls inside the stated range.
By their numbers in this assay, from the lowest: compounds 1, 2 and 3 (each within the scatter of the next, the first and the last beyond it).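

Methyl in place of hydrogen on the amide-type nitrogen gives a number 9.2 percentage points higher from compound 2 to compound 3 (within the scatter) and so does not separate the dimethylcarbamoyl compound from the methylcarbamoyl compound at this position. Set against the acid, however, dimethylamino in place of hydroxy on the carbonyl carbon gives a number 12.9 percentage points higher from compound 1 to compound 3 (beyond the scatter) and thus provides the first modest change in this assay that can be told from the scatter, which methylamino at the same carbonyl carbon did not provide. Nothing measured explains this difference between the two amides and the acid.

The compounds shown leave open whether ethyl on the nitrogen, in place of either methyl, would keep the number where it stands or move it. They also leave open how an unsubstituted amino group on the carbonyl carbon would compare with hydroxy, methylamino and dimethylamino there.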